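Swapping nitro for trifluoromethyl on compound 1

The source may hold more compounds than are shown below. What is called first, only, known or untested is meant among the compounds shown, and "the series" means these compounds.

Measured in an in vitro ADME assay on microsomes from liver (Homo sapiens) for metabolic stability, tested at 1 uM; on this read-out lower numbers stand for a shorter-lived compound and higher numbers for a longer-lived compound:
- compound 1 `Cc1cc(/C=C/C#N)cc(C)c1Oc1cc(Nc2ccc(C#N)cc2)c(N)cc1[N+](=O)[O-]` gives 0.797 h
- compound 2 `COC(=O)c1cc(N)c(Nc2ccc(C#N)cc2)cc1Oc1c(C)cc(CCC#N)cc1C` gives 3.1 h
- compound 3 `Cc1cc(CCC#N)cc(C)c1Oc1cc(Nc2ccc(C#N)cc2)c(N)cc1C(N)=O` gives 0.7 h

Compound 1 sits level with compound 3 within the scatter, and both lie under compound 2 by a gap beyond the scatter. The step now followed leads to compound 4 `Cc1cc(/C=C/C#N)cc(C)c1Oc1cc(Nc2ccc(C#N)cc2)c(N)cc1C(F)(F)F`, which carries trifluoromethyl in place of nitro on an aromatic carbon. Among the compounds with values here, only one measured step bears on this change, and it does so indirectly. It is a 4.4-fold lower number from compound 2 to compound 3 (0.65 log units; beyond the scatter), a modest step beyond the scatter, with amino in place of methoxy on a carbonyl carbon. That change falls within the group standing where compound 1 has its nitro, so the group at this place can move the half-life. However, compounds 2 and 3 also differ from compound 1 elsewhere, and no measured pair shows nitro or trifluoromethyl changing alone. The direction therefore stays uncertain, and only a slight rise is expected in this assay, probably not beyond the scatter. The estimate amounts to a 1.4-fold higher number from compound 1 to compound 4 (0.14 log units; within the scatter). Compound 4 is expected at 1.1 h, with an estimated range from 0.45 h to 3 h.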

Compound 4, half-life: 0.75 h
Beside the measured number, compound 4's estimate is 1.5-fold (0.17 log units) above it; the measured number falls inside the stated range.
By their numbers in this assay, from the lowest: compounds 3, 4 and 1 (each within the scatter of the next); then compound 2.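

In this assay, within the data shown here, trifluoromethyl in place of nitro, on the aromatic carbon meta to the amino group and para to the (4-cyanophenyl)amino group, gives a 1.1-fold lower number from compound 1 to compound 4 (0.03 log units; within the scatter), the first direct reading of these two groups against each other, and on the core of compound 1 the half-life does not tell them apart. The place is therefore not sensitive to every exchange: a 4.4-fold lower number from compound 2 to compound 3 (0.65 log units; beyond the scatter) is beyond the scatter, whereas the new step is within it, although the two steps stand on different side chains and so cannot be set against each other as a clean comparison. No supporting data bear on why the two groups read alike here.

On these data alone, it remains open whether the methyl ester of compound 2, at 3.1 h, would keep its longer half-life at this place when carried onto the side chain of compound 1. Also open, as far as these compounds go, is how a carboxylic acid, a chlorine or a plain hydrogen on this aromatic carbon would read on the same core.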